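Ureas at Whole-Plant Level: Swapping Tert-Butyl for Trifluoromethyl

The compounds below may be only part of what the source reports. "The series", "measured", "known", "first", "only" and "open" are said of these compounds alone.

Compound 2, `C[C@H](NC(=O)Nc1ccccc1C(C)(C)C)c1ccccc1`, is one of two ureas that have been measured in an ADME assay on the whole organism with Oryza sativa as the target, tested at 1 uM; on this read-out higher numbers stand for a weaker effect at the one concentration tested and lower numbers for a stronger effect. In this assay compound 2 gives 99%. Its nearest neighbour is compound 1, `Cc1ccccc1NC(=O)N[C@@H](C)c1ccccc1`, which in this assay gives 99%. Going by the values given here, the one measured step, no change at the digits printed from compound 1 to compound 2 (within the scatter), shows that the change of tert-butyl in place of methyl on an aromatic carbon left the read-out where it was, within the scatter. Compound 2 therefore stands level with compound 1 on the numbers available, with nothing to separate them.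

The next compound, compound 3, `C[C@H](NC(=O)Nc1ccccc1C(F)(F)F)c1ccccc1`, differs from compound 2 in one place: trifluoromethyl in place of tert-butyl on an aromatic carbon. Among the compounds with values here, the only step that bears on this change is the earlier one from compound 1 to compound 2, which was no change within the scatter at the same position. On that basis the expected step in this assay is a number 2 percentage points lower from compound 2 to compound 3 (within the scatter), a movement of no size beyond the scatter in either direction. The estimate for compound 3 is accordingly 97%, with a range from 85% to 100%.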

Compound 3, a percentage reported as activity, at one concentration (the size of the read-out at that concentration, not a potency): 98%
For compound 3 the middle estimate is 1 percentage points below the measured one; the measured number falls inside the stated range.
By their numbers in this assay, from the lowest: compounds 3, 1 and 2 (each within the scatter of the next).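

Going by these compounds alone, the change to trifluoromethyl brings fluorine to this position for the first time, in a group with the same count of heavy atoms as tert-butyl, and this assay records a number 1 percentage points lower from compound 2 to compound 3 (within the scatter) as the result. The position has now carried methyl, tert-butyl and trifluoromethyl, and the direct comparison of the smallest and the fluorinated group gives a number 1 percentage points lower from compound 1 to compound 3 (within the scatter), so none of the three exchanges among these compounds separates them on this read-out, and the earlier finding no longer rests on groups built from carbon alone. Nothing available accounts for this lack of separation, which therefore stands as an observation only.

From the compounds shown here alone, what remains open is whether any group on this aromatic carbon can move the read-out beyond the scatter, since an amine, a carboxylic acid or a longer chain there would test the position with groups unlike these three. The compounds also leave open whether the same flat picture would hold at other concentrations, or with changes elsewhere on the shared core, as every comparison so far rests on a single position and a single concentration.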